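The compounds below may be only part of what the source reports. "The series", "measured", "known", "first", "only" and "open" are said of these compounds alone.

Compound 1 `O=C(CN1CCN(c2nnc(Cc3ccccc3)c3ccccc23)CC1)Nc1c(F)cccc1F` gives 19700 nM in a functional assay on HT-29 cells (Homo sapiens) for cytotoxicity, read by MTT assay, with a stated time of 72 h; a lower number here means a stronger inhibitor, a higher number a weaker inhibitor.
Compound 2 `O=C(CN1CCN(c2nnc(Cc3ccccc3)c3ccccc23)CC1)Nc1cc(C(F)(F)F)ccc1Cl` gives 66800 nM in this assay.
Compound 3 `O=C(CN1CCN(c2nnc(Cc3ccncc3)c3ccccc23)CC1)Nc1cc(C(F)(F)F)ccc1Cl` gives 4810 nM in this assay.

All three share the same core and differ in only two places. Compound 2 and compound 1 differ on the amide-type nitrogen: 2,6-difluorophenyl in place of 2-chloro-5-(trifluoromethyl)phenyl on an amide-type nitrogen. That exchange gave a 3.4-fold lower number from compound 2 to compound 1 (0.53 log units; beyond the scatter). Compound 2 and compound 3 differ in the ring on the saturated chain carbon: pyridin-4-yl in place of phenyl on a saturated chain carbon bound to an aromatic carbon. That exchange gave a 14-fold lower number from compound 2 to compound 3 (1.14 log units; beyond the scatter). Compound 3 therefore has the lowest number of the three, and its steps from compound 1 and from compound 2 both lie beyond the scatter, so it is the strongest inhibitor among the measured compounds.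

Compound 4 `O=C(CN1CCN(c2nnc(Cc3ccncc3)c3ccccc23)CC1)Nc1c(F)cccc1F` has not yet been measured. It keeps the pyridin-4-yl ring of compound 3 and takes the amide substituent of compound 1: 2,6-difluorophenyl in place of 2-chloro-5-(trifluoromethyl)phenyl on an amide-type nitrogen. The place is described in the same words as for the change from compound 2 to compound 1, so this is the same change, made once before among these compounds.

The expectation for compound 4 rests on that single earlier example, because the same exchange gave a 3.4-fold lower number from compound 2 to compound 1 (0.53 log units; beyond the scatter) when made on the phenyl-bearing core. For compound 4 the expected step is a 3.2-fold lower number from compound 3 to compound 4 (0.51 log units; beyond the scatter). Among the compounds with values here, with only one precedent the range is kept wide. Compound 4 is estimated at 1500 nM in this assay, expected to fall between 500 nM and 4500 nM.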

Compound 4, half-maximal inhibitory concentration: 28700 nM
For compound 4 the middle estimate is 19-fold (1.28 log units) below the measured one, and the stated range ends below it.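

On the core carrying pyridin-4-yl, 2,6-difluorophenyl in place of 2-chloro-5-(trifluoromethyl)phenyl gave a 6.0-fold higher number from compound 3 to compound 4 (0.78 log units; beyond the scatter) in this assay, so the earlier result did not carry over and its direction reversed: the same change on two cores in this assay, a 3.4-fold lower number (0.53 log units; beyond the scatter) from compound 2 to compound 1 and a 6.0-fold higher number (0.78 log units; beyond the scatter) from compound 3 to compound 4, 20-fold (1.31 log units) apart, beyond the scatter of two such steps

The ring exchange did not carry over either, since pyridin-4-yl in place of phenyl gave a 1.5-fold higher number from compound 1 to compound 4 (0.16 log units; within the scatter) with 2,6-difluorophenyl on the amide-type nitrogen, a step within the scatter, although the same exchange had given a large step with the other amide substituent: the same change on two cores in this assay, a 14-fold lower number (1.14 log units; beyond the scatter) from compound 2 to compound 3 and a 1.5-fold higher number (0.16 log units; within the scatter) from compound 1 to compound 4, 20-fold (1.31 log units) apart, beyond the scatter of two such steps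

Across these four compounds, then, the result of a change in one place depends on what sits in the other, but they do not show why, and with one pair of steps for each change they cannot show whether this holds for other groups.

The compounds shown leave open how other groups on the amide-type nitrogen, such as a plain phenyl or a phenyl carrying only a chlorine, would behave on each core. They also leave open whether a pyrimidine ring or a simple amine in place of pyridin-4-yl would follow compound 3 or compound 4.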